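The source may report more compounds than this note shows. Statements on the series, on what has been measured and on what is new or still open speak of the compounds shown alone.

Compound 2 `Cc1ccccc1C1CC(c2ccc(Oc3ccccc3)cc2)=NN1c1ccc(S(N)(=O)=O)cc1` is measured in an ADME assay on BHK-21 cells (Mesocricetus auratus) for cytotoxicity, read by MTT assay, with a stated time of 72 h (on this read-out higher numbers stand for lower toxicity in this test and lower numbers for higher toxicity in this test), where compound 2 gives 7000 nM. Its one measured neighbour, compound 1 `NS(=O)(=O)c1ccc(N2N=C(c3ccc(Oc4ccccc4)cc3)CC2c2ccccc2Cl)cc1`, gives 8000 nM in this assay, and the two differ only by a 1.1-fold lower number from compound 1 to compound 2 (0.06 log units; within the scatter), within the scatter, so compound 2 stands level with compound 1 on the numbers shown. Compound 3 `Cc1ccc(C2CC(c3ccc(Oc4ccccc4)cc3)=NN2c2ccc(S(N)(=O)=O)cc2)cc1` differs from compound 2 by 4-methylphenyl in place of 2-methylphenyl on a saturated ring carbon. Within the data shown here, no measured step concerns a shift of the methyl around that ring; the only step, a 1.1-fold lower number from compound 1 to compound 2 (0.06 log units; within the scatter), touched the same place and stayed within the scatter, so no step beyond the scatter is expected. Compound 3 is therefore estimated at 7000 nM, between 3500 nM and 14000 nM, which means an expected no change at the digits printed from compound 2 to compound 3 (within the scatter).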

Compound 3, half-maximal cytotoxic concentration: 8000 nM
The estimate for compound 3 lay 1.1-fold (0.06 log units) below the measured number; low and high end bracket the measured number.
By their numbers in this assay, from the lowest: compounds 2, 1 and 3 (each within the scatter of the next).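

In this assay, moving the methyl from 2-methylphenyl to 4-methylphenyl on the saturated ring carbon gives a 1.1-fold higher number from compound 2 to compound 3 (0.06 log units; within the scatter), and 4-methylphenyl in place of 2-chlorophenyl gives no change at the digits printed from compound 1 to compound 3 (within the scatter). This place, so far probed only by methyl in place of chloro, now shows that a changed attachment point on the aromatic ring also leaves the number within the scatter. No evidence on hand accounts for this.

From the compounds shown here alone, whether an amine, a carboxylic acid or a longer chain on that aromatic ring would produce a step beyond the scatter remains open.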